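The source may report more compounds than this note shows. Statements on the series, on what has been measured and on what is new or still open speak of the compounds shown alone.

In a functional assay on THP-1 cells (Homo sapiens) (on this read-out higher numbers stand for weaker inhibition and lower numbers for stronger inhibition), compound 1 (`COc1ccc([C@H](Nc2cccc3nc(C)ccc23)[C@](O)(CN(C)C)C(F)(F)F)c(Cl)c1F`) gives 5.01 nM while compound 2 (`CCSC[C@@](O)([C@@H](Nc1cc(F)cc2[nH]c(=O)ccc12)c1ccc(OC)c(F)c1Cl)C(F)(F)F`) gives 1.59 nM as the lower of the two numbers, a gap beyond the usual scatter. Compound 3 (`CCOC[C@@](O)([C@@H](Nc1cc(F)cc2[nH]c(=O)ccc12)c1ccc(OC)c(F)c1Cl)C(F)(F)F`) carries ethoxy in place of ethylsulfanyl on a saturated chain carbon, two bonds along the chain from an oxygen on a saturated carbon. Among the compounds with values here, no measured pair shows this swap, so in this assay only a small rise in the number, within the scatter, is expected. The estimated step runs a 1.6-fold higher number from compound 2 to compound 3 (0.20 log units; within the scatter) and stays small. For compound 3 the expected value is 2.5 nM with an estimated range from 0.8 nM to 8 nM as the likely span.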

Compound 3, half-maximal inhibitory concentration in the THP-1 assay: 0.794 nM
Compound 3: the middle estimate sits 3.1-fold (0.50 log units) above what was measured, outside the stated range (below it).
By their numbers in the THP-1 assay, from the lowest: compounds 3 and 2 (each within the scatter of the next); then compound 1.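

At this place, on a saturated chain carbon, two bonds along the chain from an oxygen on a saturated carbon, ethoxy can replace ethylsulfanyl while the inhibition in the THP-1 assay holds, with a 2.0-fold lower number from compound 2 to compound 3 (0.30 log units; within the scatter). In a physicochemical assay for lipophilicity (on this read-out lower numbers stand for lower lipophilicity and higher numbers for higher lipophilicity), compound 2 gives 4.3 and compound 3 gives 3.8. The same swap does change lipophilicity, so the inhibition stays level while the number in the physicochemical assay falls: the measured partition coefficient of compound 2, 4.3, and of compound 3, 3.8, a number 0.50 log units lower (beyond the scatter)

The compounds shown leave open how a longer chain such as propoxy, or a carboxylic acid, would fare here. A single pair also cannot tell whether this swap would behave the same way on another core.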